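The source may report more compounds than this note shows. Statements on the series, on what has been measured and on what is new or still open speak of the compounds shown alone.

Compound 1 `O=C1/C(=C/c2cccc([N+](=O)[O-])c2)CN(S(=O)(=O)c2ccc(F)cc2)C/C1=C\c1ccccc1F`, compound 2 `N#Cc1ccc(/C=C2\CN(S(=O)(=O)c3ccc(F)cc3)C/C(=C\c3ccccc3F)C2=O)cc1` and compound 3 `COc1cc(/C=C2\CN(S(=O)(=O)c3ccc(F)cc3)C/C(=C\c3cccc([N+](=O)[O-])c3)C2=O)cc(OC)c1OC` were tested in a functional assay on QGY-7703 cells (Homo sapiens) for cytotoxicity, read by MTT assay, with a stated time of 24 h; a higher number here means a weaker inhibitor, a lower number a stronger inhibitor. Compound 1 gives 14900 nM in this assay, compound 2 gives 20100 nM, and compound 3 gives 3270 nM. The change from compound 1 to compound 2 is 4-cyanophenyl in place of 3-nitrophenyl on a double-bonded chain carbon bound to a double-bonded ring carbon, and it made a step of a 1.3-fold higher number from compound 1 to compound 2 (0.13 log units; within the scatter). The change from compound 1 to compound 3 is 3,4,5-trimethoxyphenyl in place of 2-fluorophenyl on a double-bonded chain carbon bound to a double-bonded ring carbon, giving a step of a 4.6-fold lower number from compound 1 to compound 3 (0.66 log units; beyond the scatter). Compound 4 `COc1cc(/C=C2\CN(S(=O)(=O)c3ccc(F)cc3)C/C(=C\c3ccc(C#N)cc3)C2=O)cc(OC)c1OC` has not yet been measured. It differs from compound 3 by 4-cyanophenyl in place of 3-nitrophenyl on a double-bonded chain carbon bound to a double-bonded ring carbon, the same change as between compound 1 and compound 2, on a core that differs by 3,4,5-trimethoxyphenyl in place of 2-fluorophenyl on a double-bonded chain carbon bound to a double-bonded ring carbon. Because the earlier step was a 1.3-fold higher number from compound 1 to compound 2 (0.13 log units; within the scatter), a step of about a 1.3-fold higher number from compound 3 to compound 4 (0.12 log units; within the scatter) is expected here. Compound 4 is therefore estimated at 4300 nM, likely between 1800 nM and 10000 nM.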

Compound 4, half-maximal inhibitory concentration: 4980 nM
Estimate against measurement, compound 4: 1.2-fold (0.06 log units) below; the range from low to high includes it.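

With 4-cyanophenyl in place of 3-nitrophenyl, the result is a 1.5-fold higher number from compound 3 to compound 4 (0.18 log units; within the scatter), and this step carries over from the other core: the same change on two cores in this assay, a 1.3-fold higher number (0.13 log units; within the scatter) from compound 1 to compound 2 and a 1.5-fold higher number (0.18 log units; within the scatter) from compound 3 to compound 4, 1.1-fold (0.05 log units) apart, within the scatter of two such steps. With 3,4,5-trimethoxyphenyl in place of 2-fluorophenyl, the result is a 4.0-fold lower number from compound 2 to compound 4 (0.61 log units; beyond the scatter), and this step also carries over: the same change on two cores in this assay, a 4.6-fold lower number (0.66 log units; beyond the scatter) from compound 1 to compound 3 and a 4.0-fold lower number (0.61 log units; beyond the scatter) from compound 2 to compound 4, 1.1-fold (0.05 log units) apart, within the scatter of two such steps. Each change thus behaved alike on the two cores shown, but this rests on four compounds in this assay and does not show that it would hold on other cores or explain why the steps match.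

The compounds shown leave open whether an amine or a carboxylic acid at the same place would carry over as closely. They also leave open whether either change would behave alike with a different group on the sulfonyl.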